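From Urea to Amide on a Shared Core

The source may hold more compounds than are shown below. What is called first, only, known or untested is meant among the compounds shown, and "the series" means these compounds.

Compound 3 `COc1cc(Cl)cc(-c2nn(-c3cccc(NC(=O)Nc4cccc(C(F)(F)F)c4)c3)cc2-c2ccncc2)c1` gives 47% in a functional assay on U-251 cells (Homo sapiens) for inhibition, read by sulforhodamine B assay, with a stated time of 48 h, tested at 1 uM (a lower number here means a stronger effect, a higher number a weaker effect of the compound at the concentration tested), the second highest of three numbers. Compound 1 `COc1cc(Cl)cc(-c2nn(-c3cccc(NC(=O)Nc4ccc(Cl)c(C(F)(F)F)c4)c3)cc2-c2ccncc2)c1` gives 43%, and the step of a number 4 percentage points higher from compound 1 to compound 3 (within the scatter) is within the scatter. Compound 2 `COc1cc(Cl)cc(-c2nn(-c3cccc(NC(=O)Nc4ccc(Cl)c(Cl)c4)c3)cc2-c2ccncc2)c1` gives 71%, and the step of a number 24 percentage points lower from compound 2 to compound 3 (beyond the scatter) lies beyond it. Compound 4 `COc1cc(Cl)cc(-c2nn(-c3cccc(NC(=O)c4cccc(C(F)(F)F)c4)c3)cc2-c2ccncc2)c1` differs from compound 3 by 3-(trifluoromethyl)phenyl in place of (3-(trifluoromethyl)phenyl)amino on a carbonyl carbon. The measured steps, a number 28 percentage points higher from compound 1 to compound 2 (beyond the scatter) and a number 24 percentage points lower from compound 2 to compound 3 (beyond the scatter), exchange chloro, trifluoromethyl and hydrogen on an aromatic carbon; none of them touches the link to the carbonyl, so none bears directly on this change. Without a guide, no step beyond the scatter is expected, and the estimated step is a number 8 percentage points higher from compound 3 to compound 4 (within the scatter). Compound 4 is therefore expected to give about 55%, between 30% and 85%.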

Compound 4, a percentage reported as activity, at one concentration (the size of the read-out at that concentration, not a potency): 65%
Compound 4: middle estimate off by 10 percentage points, on the low side; the measured number falls inside the stated range.
By their numbers in this assay, from the lowest: compounds 1 and 3 (each within the scatter of the next); then compounds 4 and 2 (each within the scatter of the next).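

In this assay, among these compounds, this is the first change at the link to the carbonyl, and taking away the amino nitrogen with its hydrogen weakens the effect (a number 18 percentage points higher from compound 3 to compound 4 (beyond the scatter)). The same holds against compound 1 (a number 22 percentage points higher from compound 1 to compound 4 (beyond the scatter)), whereas compound 4 cannot be told apart from compound 2 (a number 6 percentage points lower from compound 2 to compound 4 (within the scatter)), so the link matters about as much here as the ring substituents did. Nothing measured here explains the shift.

On these data alone, it remains open how a longer carbon chain carrying 3-(trifluoromethyl)phenyl on the carbonyl carbon would read, and whether chloro on the ring of compound 4 would move the number as it did among the ureas.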